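This account rests on a few compounds, and the source may have more. Where it says the series, first, only, none or still open, it means among the compounds named here.

Of the compounds shown here, three that share a core have been tested in a functional assay on the whole organism (Abdomen, strain Swiss) for inhibition, with Mus musculus as the target, with stated times of 30 min, 10 min and 5 min, at a dose of 10 mg/kg by the oral route; a higher number here means a stronger effect of the compound at the dose given, a lower number a weaker effect. Compound 1, `C=Cc1c(CCC)nn(CCCN2CCN(c3ccc(C)cc3)CC2)c(=O)c1N`, gives 3% in this assay. Compound 2, `C=Cc1c(CCCC)nn(CCCN2CCN(c3ccc(C)cc3)CC2)c(=O)c1N`, gives 0% in this assay. Compound 3, `CC/C=C/c1c(C)nn(CCCN2CCN(c3ccc(C)cc3)CC2)c(=O)c1N`, gives 5% in this assay. Compound 3 and compound 1 are built from the same atoms joined differently; the difference between the two cores is not broken down here. All three values lie within the usual scatter of one another, so none of the three can be said to act more or less strongly than the others at this dose.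

Compound 2 differs from compound 1 by a single change, (methyl in place of hydrogen on a saturated chain carbon, three bonds along the chain from an aromatic carbon). That change produced a number 3 percentage points lower from compound 1 to compound 2 (within the scatter).

Compound 4, `CCC/C=C/c1c(C)nn(CCCN2CCN(c3ccc(C)cc3)CC2)c(=O)c1N`, has not yet been measured. It differs from compound 3 by methyl in place of hydrogen on a saturated chain carbon, two bonds along the chain from a double-bonded chain carbon. Among the compounds with values here, this is the same kind of change as the one from compound 1 to compound 2, but its surroundings differ: in compound 2 the added methyl sits on a saturated chain carbon three bonds along the chain from an aromatic carbon, whereas in compound 4 it sits on a saturated chain carbon two bonds along the chain from a double-bonded chain carbon.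

Within the data shown here, a step of a number 2 percentage points lower from compound 3 to compound 4 (within the scatter) is expected because the one earlier step of this kind gave a number 3 percentage points lower from compound 1 to compound 2 (within the scatter). Compound 4 is therefore expected to give about 3% in this assay, with a likely span from 0% to 10%.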

Compound 4, a percentage reported as inhibition, in the whole organism at one dose (the size of the read-out at that dose, not a potency): 0%
For compound 4 the middle estimate is 3 percentage points above the measured one; measured number inside the range.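

In this assay the added methyl gave a number 5 percentage points lower from compound 3 to compound 4 (within the scatter) and so, taken alone, this step shows no real change in the effect at the dose given. Set beside the earlier step on the other core, the same change behaves alike on both cores as far as this kind of measurement can tell: the same change on two cores in this assay, a number 3 percentage points lower (within the scatter) from compound 1 to compound 2 and a number 5 percentage points lower (within the scatter) from compound 3 to compound 4, 2 percentage points apart, within the scatter of two such steps

Within the data shown here, this shows that the change can be carried from one core to the other here without any visible difference, but it rests on only two pairs of compounds, and neither step stands clear of the scatter, so it does not show that the change has any real effect on either core or that it would behave the same way on a compound with a clear effect at this dose.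

The compounds shown differ only in their hydrocarbon chains on the shared core, which leaves open whether a group of another kind at the end of such a chain, such as an amine or a carboxylic acid, would give a step beyond the scatter. Also open, going by these compounds, is what a chain longer than pent-1-en-1-yl would do.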